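A few compounds are considered here, and "the series" means these few. Any claim that something is new, unique, unknown or untested is made for them only; others in the source may bear on it.

Measured so far in a functional assay on ACHN cells (Homo sapiens) for antiproliferative activity, read by sulforhodamine B assay (a higher number here means a weaker inhibitor of growth, a lower number a stronger inhibitor of growth), are two compounds
- compound 1 `CC(C)CCCOc1cccc(O)c1C(=O)/C=C/c1ccc(O)cc1` at 3630 nM
- compound 2 `CC(C)(C)CCOc1cccc(O)c1C(=O)/C=C/c1ccc(C(=O)O)cc1` at 8450 nM

Compound 2 at 8450 nM holds the higher of the two numbers, and its gap to compound 1 lies beyond the scatter. Compound 3 `CC(C)(C)CCOc1cccc(O)c1C(=O)/C=C/c1ccc(O)cc1` differs from compound 2 by hydroxy in place of carboxy on an aromatic carbon, para to a large group, a change counted as hydroxy in place of carboxy on an aromatic carbon in full. Among the measured compounds shown here, no step between measured compounds covers this change. Compound 1 at 3630 nM also bears 4-hydroxyphenyl, so a modest fall in this assay is expected, little beyond the scatter. The expected step is a 2.3-fold lower number from compound 2 to compound 3 (0.37 log units; beyond the scatter) in size. For compound 3 the estimate is 3600 nM within a range of 1500 nM to 8000 nM overall.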

Compound 3, concentration for 50% growth inhibition: 3140 nM
The estimate for compound 3 lay 1.1-fold (0.06 log units) above the measured number; measured number inside the range.
By their numbers in this assay, from the lowest: compounds 3 and 1 (each within the scatter of the next); then compound 2.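

In this assay, among the compounds shown here, hydroxy in place of carboxy on this aromatic carbon gives a 2.7-fold lower number from compound 2 to compound 3 (0.43 log units; beyond the scatter) as a modest step, the first direct reading of this change at this place. With 4-hydroxyphenyl held, tert-butyl in place of isobutyl gives a 1.2-fold lower number from compound 1 to compound 3 (0.06 log units; within the scatter) and so does not separate the two chains. No supporting data bear on this result. Going by these compounds, whether an amine, a methoxy group or a fluorine at this place would read closer to hydroxy or to carboxy stays open. So does the effect of a longer chain on the oxygen.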